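The source may report more compounds than this note shows. Statements on the series, on what has been measured and on what is new or still open speak of the compounds shown alone.

Compound 1 `C[C@@H]1CN(c2cccc3c2C[C@H](CN(C)[C@H]2CCCc4cccnc42)NC3)C[C@H](C)N1` sits among the higher numbers shown in an ADME assay on microsomes from liver (Mus musculus) for metabolic stability, read by LC-MS, with a stated time of 10 min (a higher number here means that more of the compound is left, a lower number that less of the compound is left), giving 85.6%. Compound 3 `CCCN(C[C@H]1Cc2c(cccc2N2CCNCC2)CN1)[C@H]1CCCc2cccnc21` gives 87.4%, which lies within the scatter of compound 1, while compound 2 `CCN(C[C@H]1Cc2c(cccc2N2CCNCC2)CN1)[C@H]1CCCc2cccnc21` gives 53.8%, beyond the scatter and well below. Within the data shown here, the single step measured at one place, a number 33.6 percentage points higher from compound 2 to compound 3 (beyond the scatter), concerns the chain on the amine nitrogen and not the group on the aromatic carbon. Compound 4 `CN(C[C@H]1Cc2c(cccc2N2C[C@@H]3C[C@H]2CN3)CN1)[C@H]1CCCc2cccnc21` differs from compound 1 by a group of 7 heavy atoms (5 carbon, 2 nitrogen; 2 five-membered non-aromatic rings with 1 hetero atom each) in place of a group of 8 heavy atoms (6 carbon, 2 nitrogen; one six-membered non-aromatic ring with 2 hetero atoms), on an aromatic carbon. Among the measured compounds shown here, no measured step touches this place, so the three compounds give no direct guide; the expectation is a step of a number 15.6 percentage points lower from compound 1 to compound 4 (beyond the scatter), likely within or just beyond the scatter, with a wide margin. Compound 4 is estimated at 70%, ranging from 45% to 92%.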

Compound 4, percent of the compound remaining: 36.3%
The estimate for compound 4 lay 33.7 percentage points above the measured number, and the stated range ends above it.
By their numbers in this assay, from the lowest: compound 4; then compound 2; then compounds 1 and 3 (each within the scatter of the next).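

In this assay, the group on the aromatic carbon proves to be a second place where the read-out moves: the two-ring group of compound 4 in place of 3,5-dimethylpiperazin-1-yl gives a number 49.3 percentage points lower from compound 1 to compound 4 (beyond the scatter). The two groups have equal hydrogen-bond donor and acceptor counts and no net charge, so these counts do not separate them. Nothing available bears on the reason for this drop.

Open, going by these compounds, is whether the two methyl groups or the ring shape carry the difference. A morpholine at this aromatic carbon, or an unsubstituted piperazin-1-yl with the amine chain of compound 1, would help to separate these.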